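From pyridin-2-yl to 3-methylthiophen-2-yl: cytotoxicity notes

The source may report more compounds than this note shows. Statements on the series, on what has been measured and on what is new or still open speak of the compounds shown alone.

Compound 1 `CC(C)CN1C(=O)/C(=C/c2ccc(Cl)cc2)S/C1=N\c1ccccc1` has no usable result in an ADME assay on HepG2 cells (Homo sapiens) for cytotoxicity, read by MTT assay, with a stated time of 48 h (on this read-out higher numbers stand for weaker inhibition and lower numbers for stronger inhibition), where its entry reads "not determined" (no result reported). Compound 2 `CC(C)CN1C(=O)/C(=C/c2ccccn2)S/C1=N\c1ccccc1` gives > 100000 nM in this assay, and this is a limit of the assay, not a number. Among the measured compounds shown here, the series so far rests on (the limit of > 100000 nM in this assay, at which 1 of the 2 values shown sits). Compound 3 `Cc1ccsc1/C=C1\S/C(=N\c2ccccc2)N(CC(C)C)C1=O` has 3-methylthiophen-2-yl in place of pyridin-2-yl on a double-bonded chain carbon bound to a double-bonded ring carbon. For the measured compounds named here, no measured step gives a size for such a change, so no shift beyond the scatter is expected in this assay. The expected step, small and if anything toward stronger inhibition, is an at least 1.1-fold lower number from compound 2 to compound 3 (0.04 log units; that floor lies within the scatter). For compound 3 the estimated value is 90000 nM, with an expected range of 30000 nM to 250000 nM.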

Compound 3, half-maximal inhibitory concentration in the HepG2 assay: 89200 nM
Compound 3: the middle estimate sits 1.0-fold (0.00 log units) above what was measured; the range from low to high includes it.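

In the HepG2 assay compound 2 gives > 100000 nM, which is a limit of the assay and not a number. Measured against that limit, 3-methylthiophen-2-yl in place of pyridin-2-yl on a double-bonded chain carbon bound to a double-bonded ring carbon gives the first step at this place, an at least 1.1-fold lower number from compound 2 to compound 3 (0.04 log units; that floor lies within the scatter), so only a floor can be read and no shift beyond the scatter is shown. In a physicochemical assay for lipophilicity, measured as octanol-water partition (on this read-out lower numbers stand for lower lipophilicity and higher numbers for higher lipophilicity), compound 2 gives 4.4 and compound 3 gives 5.81. In the physicochemical assay the same change does move the number clearly: the measured partition coefficient of compound 2, 4.4, and of compound 3, 5.81, a number 1.41 log units higher (beyond the scatter)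

As far as these compounds go, the true size of the step in the HepG2 assay stays open, as a floor does not fix it. Also open, from the compounds shown here alone, is how a phenyl carrying a carboxylic acid or a dimethylamino group would read at this place in both assays.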